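A few compounds are considered here, and "the series" means these few. Any claim that something is new, unique, unknown or untested is made for them only; others in the source may bear on it.

As far as these compounds go, in a functional assay on A549 cells (Homo sapiens) for inhibition (a lower number here means a stronger inhibitor, a higher number a weaker inhibitor), compound 3 `CCN(CC)CCNC(=O)CC(CC(=O)N(C)C1Cc2ccccc2C1)c1ccccc1` is reported only as a limit, > 100000 nM, so its true place on the scale is unknown. Compound 2 `CN(C(=O)CC(CC(=O)NCCN1CCCC1)c1ccccc1)C1Cc2ccccc2C1` is also reported only as a limit, > 100000 nM. Going by the values given here, the single measured step, a step that the two limits leave unreadable from compound 2 to compound 3, therefore offers no size to build on. Compound 4 `CCN(CC)CCNC(=O)CC(CC(=O)N(C)C1Cc2ccccc2C1)c1ccc(Cl)cc1` differs from compound 3 by chloro in place of hydrogen on an aromatic carbon, para to a large group: chloro in place of hydrogen on an aromatic carbon. Among the compounds with values here, compound 1 `CCN(CC)CCNC(=O)CC(CC(=O)NC1Cc2ccccc2C1)c1ccc(Cl)cc1` also carries a 4-chlorophenyl group and is the only compound with a real number, 48600 nM. On that slender basis, a modest shift toward stronger inhibition is expected, an estimated at least 1.4-fold lower number from compound 3 to compound 4 (0.15 log units; that floor lies within the scatter). For compound 4 the estimate is 70000 nM, within an expected range of 30000 nM to 130000 nM.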

Compound 4, half-maximal inhibitory concentration: 21400 nM
Beside the measured number, compound 4's estimate is 3.3-fold (0.51 log units) above it; measured number below the stated range.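

In this assay, 4-chlorophenyl in place of phenyl gives the first readable gain at this position, an at least 4.6-fold lower number from compound 3 to compound 4 (0.66 log units; beyond the scatter), and the true gain may be larger. That size is only a floor, because compound 3 stands at a limit rather than a number: the limit of > 100000 nM in this assay, at which 2 of the 4 values shown sit. With the chloro group in place, methyl on the amide-type nitrogen also counts, giving a 2.3-fold lower number from compound 1 to compound 4 (0.36 log units; beyond the scatter).

As far as these compounds go, whether fluoro, methoxy or a carboxylic acid at this position would match chloro stays open. So does whether that methyl has any effect on the phenyl compounds.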